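From 4-methoxyphenyl to 3,5-difluorophenyl on the shared core

The source may hold more compounds than are shown below. What is called first, only, known or untested is meant among the compounds shown, and "the series" means these compounds.

- compound 1 `Cc1cn(C2CCN(Cc3cccc(Oc4cc(Cl)cc(Cl)c4)c3)CC2)c(=O)[nH]c1=O`: 6730 nM
- compound 2 `COc1ccc(Oc2cccc(CN3CCC(n4cc(C)c(=O)[nH]c4=O)CC3)c2)cc1`: 28000 nM

These values come from an ADME assay on MRC5 cells (Homo sapiens) for cytotoxicity, read by fluorescence and resazurin assay, with a stated time of 3 days; a lower number here means a stronger inhibitor, a higher number a weaker inhibitor. Compound 2 holds the higher of the two numbers. The next change leads to compound 3 `Cc1cn(C2CCN(Cc3cccc(Oc4cc(F)cc(F)c4)c3)CC2)c(=O)[nH]c1=O`, which is still unmeasured: 3,5-difluorophenyl in place of 4-methoxyphenyl on an oxygen on an aromatic ring. In words, 3,5-difluorophenyl replaces 4-methoxyphenyl on an oxygen on an aromatic ring.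

Going by the values given here, one measured step bears on this, the modest 4.2-fold higher number from compound 1 to compound 2 (0.62 log units; beyond the scatter), which lies beyond the scatter and arose when 4-methoxyphenyl replaced 3,5-dichlorophenyl at the same place. Among the compounds with values here, no measured compound carries 3,5-difluorophenyl, so the transfer is uncertain. A step of similar or smaller size in the reverse direction is expected, towards compound 1 at 6730 nM. The expected change is a 2.2-fold lower number from compound 2 to compound 3 (0.33 log units; beyond the scatter). For compound 3 the estimate in this assay is 13000 nM, with an expected range of 5500 nM to 30000 nM.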

Compound 3, half-maximal inhibitory concentration: > 64000 nM
Compound 3: no number, only a limit; the forecaster's own chance of this, stated with the estimate: 5%; middle value at least 4.9-fold (0.69 log units) away from the limit.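

Compound 3 reads only as a limit of the assay in this assay, not as a number: the limit of > 64000 nM in this assay, at which 1 of the 3 values shown sits.

The earlier pair showed only that 4-methoxyphenyl gives a higher number than 3,5-dichlorophenyl on this oxygen, but 3,5-difluorophenyl now reverses the expected direction, with an at least 2.2-fold higher number from compound 2 to compound 3 (0.35 log units; beyond the scatter). The 3,5-dichlorophenyl and 3,5-difluorophenyl groups therefore do not read alike at this place, with an at least 9.5-fold higher number from compound 1 to compound 3 (0.97 log units; beyond the scatter), so the pattern these two groups share does not set the number in these three compounds, and the choice of halogen matters.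

Going by these compounds, how far compound 3 lies past the limit stays open, so both new steps are lower bounds only. Also open, on these data alone, is whether 3,5-dibromophenyl, or a phenyl ring carrying an amine or a carboxylic acid, would continue this spread.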